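Chalcone series on the shared core: methyl to hydrogen on ring oxygen

This account rests on a few compounds, and the source may have more. Where it says the series, first, only, none or still open, it means among the compounds named here.

Measured so far:
- compound 1 `O=C(/C=C/c1ccc(O)c(O)c1)c1cc2ccoc2cc1O`: 62.7%
- compound 2 `COc1ccc(/C=C/C(=O)c2cc3ccoc3cc2O)cc1OC`: 89.4%

Two compounds on the shared core have been run in an assay on isolated protein for inhibition of lysosomal alpha-glucosidase (Rattus norvegicus), read by spectrophotometry, with a stated time of 5 min, tested at 25 ug/mL; on this read-out higher numbers stand for more inhibition at the one concentration tested (going by the name of the read-out) and lower numbers for less inhibition. Compound 1 gives 62.7% in this assay. Compound 2 gives 89.4%, the higher of the two numbers; the gap to compound 1 lies beyond the scatter. Going by the values given here, no single-point step between these two is on hand, as they differ in more than one place, so only the two values themselves can be compared.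

Compound 3 `COc1cc(/C=C/C(=O)c2cc3ccoc3cc2O)ccc1O` is the next compound to be measured in this assay. Compared with compound 2 it carries this difference: hydrogen in place of methyl on an oxygen on an aromatic ring. Compound 3 thus sits between compound 1 and compound 2 in structure, keeping one methoxy of compound 2 and taking one hydroxy as in compound 1.

For compound 3 a moderate downward step from compound 2 is expected, of size a number 13.4 percentage points lower from compound 2 to compound 3 (beyond the scatter) in this assay, likely at or just beyond the scatter. The value for compound 3 is estimated at 76%, with a range from 58% to 90%.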

Compound 3, a percentage reported as inhibition, at one concentration (the size of the read-out at that concentration, not a potency): 52.8%
Beside the measured number, compound 3's estimate is 23.2 percentage points above it; measured number below the stated range.
By their numbers in this assay, from the lowest: compounds 3 and 1 (each within the scatter of the next); then compound 2.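

In this assay, going by these compounds alone, the change from methoxy to hydroxy now reads directly as a number 36.6 percentage points lower from compound 2 to compound 3 (beyond the scatter), the first single-change step on the shared core, and it is a large one: on this oxygen, a methyl lost from compound 2 takes away a clear part of the inhibition at the one concentration tested. The second single change, methyl in place of hydrogen on an oxygen on an aromatic ring, reads as a number 9.9 percentage points lower from compound 1 to compound 3 (within the scatter), so compound 1 and compound 3 cannot be told apart here, and of the three compounds only compound 2, with both methoxy groups, stands apart from the others. What lies behind the large step remains unexplained, as no supporting measurement bears on it.

Within the data shown here, still open is whether the high number of compound 2 needs both methoxy groups or only the one lost in compound 3, which a compound keeping that methoxy and carrying hydroxy on the other oxygen would separate. Also open, as far as these compounds go, is whether a longer ether such as ethoxy, or an amine, in place of that methoxy would hold the number of compound 2 at 89.4% in this assay.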